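This account rests on a few compounds, and the source may have more. Where it says the series, first, only, none or still open, it means among the compounds named here.

Three compounds built on one shared core have been examined in a functional assay on THP-1 cells (Homo sapiens) for cytotoxicity, read by MTT assay, with a stated time of 72 h; a lower number here means a stronger inhibitor, a higher number a weaker inhibitor. Compound 1 `CC(CC[C@H]1/C(=C/c2ccc([N+](=O)[O-])cc2)CC[C@H]2C(C)(C)CCC[C@]12C)CC(=O)O` gives 68000 nM there. Compound 2 `COc1ccc(/C=C2\CC[C@H]3C(C)(C)CCC[C@]3(C)[C@H]2CCC(C)CC(=O)O)cc1OC` gives 106000 nM in the same assay. Compound 3 `CC(CC[C@H]1/C(=C/c2ccc(Cl)cc2)CC[C@H]2C(C)(C)CCC[C@]12C)CC(=O)O` reaches only the limit of the assay, > 200000 nM, and so yields no number. Of the two numbers in hand, compound 1 has the lowest, and compound 2 stands close to it, since there is a 1.6-fold higher number from compound 1 to compound 2 (0.19 log units; within the scatter). The exchange of the nitro group for a halogen reads differently: there is an at least 2.9-fold higher number from compound 1 to compound 3 (0.46 log units; beyond the scatter). Compound 3 thus sits at the limit of > 200000 nM in this assay, at which 1 of the 3 values shown sits. Between compound 2 and compound 3 there is an at least 1.8-fold higher number from compound 2 to compound 3 (0.27 log units; that floor lies within the scatter).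

Compound 4 `CC(CC[C@H]1/C(=C/c2ccc(Br)cc2)CC[C@H]2C(C)(C)CCC[C@]12C)CC(=O)O` has not yet been measured in this assay. It differs from compound 1 in one place: bromo in place of nitro on an aromatic carbon. Among the compounds with values here, the only measured step that bears on this change is the one from nitro to chloro, which gave a higher number beyond the scatter and ended at the limit. Bromo is the other halogen here, so a higher number is expected for compound 4 as well, and the assay may again report only a limit. Compound 4 is therefore expected to give 180000 nM, within a range from 80000 nM to 400000 nM. That expectation corresponds to a 2.6-fold higher number from compound 1 to compound 4 (0.42 log units; beyond the scatter).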

Compound 4, half-maximal inhibitory concentration: > 200000 nM
Compound 4: no number, only a limit (the forecaster's own chance of this, stated with the estimate: 50%); middle value at least 1.1-fold (0.04 log units) away from the limit.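

The change from nitro on this aromatic carbon, para to a large group, now rests on two halogens rather than one: in this assay, bromo behaves like chloro and also ends at a limit, with an at least 2.9-fold higher number from compound 1 to compound 4 (0.46 log units; beyond the scatter). The exchange of the 3,4-dimethoxyphenyl group for 4-bromophenyl gives an at least 1.8-fold higher number from compound 2 to compound 4 (0.27 log units; that floor lies within the scatter), so this step alone does not separate those two compounds, just as the matching step to the chloro compound did not. Compound 3 and compound 4 now share the same limit, the step between them cannot be read, and chloro and bromo therefore cannot be told apart here: the limit of > 200000 nM in this assay, at which 2 of the 4 values shown sit.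

From the compounds shown here alone, how an amine or a trifluoromethyl group would read on this aromatic carbon stays open, as does whether fluoro would follow chloro and bromo to the limit. Also open, going by these compounds, is whether an amide in place of the carboxylic acid on the chain, which is the same in all four compounds, would change the number for the 4-nitrophenyl compound.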